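The source may hold more compounds than are shown below. What is called first, only, known or untested is meant among the compounds shown, and "the series" means these compounds.

Compound 1 `CN1CCN(c2ccc(Nc3nc(-c4cccc(NC(=O)c5ccc(C(F)(F)F)cc5)c4)sc3C(N)=O)cc2)CC1` and compound 2 `CN1CCN(c2ccc(Nc3nc(-c4cccc(NC(=O)c5ccccc5F)c4)sc3C(N)=O)cc2)CC1` share one core and differ only in the group carried on a carbonyl carbon. In a functional assay on Ramos cells (Homo sapiens) for antiproliferative activity, read by CCK-8 assay, with a stated time of 72 h, tested at 40 uM (a lower number here means less inhibition, a higher number more inhibition at the concentration tested (going by the name of the read-out)), compound 1 gives 97.8%, and in the same assay compound 2 gives 95.5%. The change between them is a number 2.3 percentage points lower from compound 1 to compound 2 (within the scatter), so the two numbers cannot be told apart. Among the compounds with values here, compound 2 stands lowest of the two numbers measured, with compound 1 as its only neighbour, and the gap between them lies within the scatter, so no order between them can be claimed.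

Compound 3 `CN1CCN(c2ccc(Nc3nc(-c4cccc(NC(=O)c5ccc(Cl)cc5)c4)sc3C(N)=O)cc2)CC1` is the next member. Its difference from compound 2 is 4-chlorophenyl in place of 2-fluorophenyl on a carbonyl carbon. Within the data shown here, the one measured step that touches this place is a number 2.3 percentage points lower from compound 1 to compound 2 (within the scatter): an exchange of one substituted phenyl for another on the same carbonyl carbon left the inhibition essentially unchanged. On that basis the step is expected to be small, a number 0.5 percentage points higher from compound 2 to compound 3 (within the scatter), with no direction beyond the scatter. Compound 3 is therefore estimated to give 96% in this assay, expected to lie between 86% and 100%.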

Compound 3, a percentage reported as inhibition, at one concentration (the size of the read-out at that concentration, not a potency): 99%
Estimate against measurement, compound 3: 3 percentage points below; low and high end bracket the measured number.
By their numbers in this assay, from the lowest: compounds 2, 1 and 3 (each within the scatter of the next).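

With a third substituted phenyl on the same carbonyl carbon, the picture from compounds 1 and 2 holds in this assay: 4-chlorophenyl in place of 2-fluorophenyl makes no difference that can be told from the scatter (a number 3.5 percentage points higher from compound 2 to compound 3 (within the scatter)). Within the data shown here, compound 3 also gives the first comparison in which a single group on an aromatic carbon is exchanged and the group on the ring remains at the same named place, chloro in place of trifluoromethyl, and this step is also within the scatter (a number 1.2 percentage points higher from compound 1 to compound 3 (within the scatter)). Among these three compounds, the inhibition at the one concentration tested is level, none goes against this, and nothing given here explains it.

From the compounds shown here alone, all three groups on this carbonyl carbon are phenyl rings carrying fluorine, chlorine or trifluoromethyl, so it remains open whether the same holds for a plain phenyl, a phenyl bearing an amine or a carboxylic acid, or a saturated group such as cyclohexyl or a longer alkyl chain. Going by these compounds, since these are readings at a single concentration rather than potencies, it also remains open whether compounds 1, 2 and 3 would separate at lower concentrations.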